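A Trifluoromethyl Swap Among Compounds at the Limit

The source may report more compounds than this note shows. Statements on the series, on what has been measured and on what is new or still open speak of the compounds shown alone.

Measured in a functional assay on CEM-SS cells (Homo sapiens) for cytotoxicity; a lower number here means a stronger inhibitor, a higher number a weaker inhibitor:
- Compound 1 `FC(F)(F)c1ccc(Cn2c(Cl)nc3cc(Cl)c(Cl)cc32)cc1` gives > 100000 nM, a limit
- Compound 2 `Cc1ccc(Cn2c(Br)nc3cc(Cl)c(Cl)cc32)cc1` gives > 100000 nM, a limit

Compound 2 has no exact value in this assay and stands only at the limit > 100000 nM. Compound 1 stands at a limit too, so the two values show no order: the limit of > 100000 nM in this assay, at which 2 of the 2 values shown sit. Compound 3 `FC(F)(F)c1ccc(Cn2c(Br)nc3cc(Cl)c(Cl)cc32)cc1` differs from compound 2 by trifluoromethyl in place of methyl on an aromatic carbon, para to a large group (trifluoromethyl in place of methyl on an aromatic carbon). Within the data shown here, no measured step shows what such a change does here. An estimated a number no higher from compound 2 to compound 3 (the limit leaves the size open) is expected, which means no step beyond the scatter in this assay. Compound 3 is expected to report a limit as well, with an estimated value of about 100000 nM and a range from 60000 nM to 200000 nM.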

Compound 3, half-maximal inhibitory concentration: > 100000 nM
Compound 3 was reported as a limit (the forecaster's own chance of this, stated with the estimate: 85%); the middle value lies on the limit itself.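

In this assay compound 3 stands at a limit, as do compound 1 and compound 2, so neither its step from compound 1 nor its step from compound 2 can be read: the limit of > 100000 nM in this assay, at which 3 of the 3 values shown sit.

The compounds shown leave open whether trifluoromethyl in place of methyl, or bromo in place of chloro, changes the read-out at all.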